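Lengthening the Ether Chain from Compound 2 to Compound 3

The compounds below may be only part of what the source reports. "The series", "measured", "known", "first", "only" and "open" are said of these compounds alone.

For the measured compounds named here, compound 2 `COCc1cc(Br)c(O)c(O)c1Br` gives 7270 nM in a functional assay on DLD-1 cells (Homo sapiens) for cytotoxicity, read by MTT assay, with a stated time of 96 h (a lower number here means a stronger inhibitor, a higher number a weaker inhibitor), the lower of the two numbers known so far. Going by the values given here, compound 1 `COCc1cc(O)c(O)c(Br)c1` gives 35300 nM, and the single measured step, a 4.9-fold lower number from compound 1 to compound 2 (0.69 log units; beyond the scatter), came from bromo in place of hydrogen on an aromatic carbon. Compound 3 `CCCOCc1cc(Br)c(O)c(O)c1Br` differs from compound 2 in one place: ethyl in place of hydrogen on a saturated chain carbon bound to an oxygen on a saturated carbon. Among the compounds with values here, no measured step concerns this chain, so none bears directly on the change. Compound 3 is therefore expected to give about 7000 nM, between 2500 nM and 20000 nM. That estimate means a step of a 1.0-fold lower number from compound 2 to compound 3 (0.02 log units; within the scatter), expected to stay within the scatter.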

Compound 3, half-maximal inhibitory concentration: 1720 nM
For compound 3 the middle estimate is 4.1-fold (0.61 log units) above the measured one; measured number below the stated range.
By their numbers in this assay, from the lowest: compound 3; then compound 2; then compound 1.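

The ether chain is a position that moves the number in this assay: methoxymethyl to propoxymethyl gives a 4.2-fold lower number from compound 2 to compound 3 (0.63 log units; beyond the scatter). Until now only the bromo change had shown a step, and this one shows that an added ethyl on the saturated chain carbon also lowers the number beyond the scatter, on a core that already carries that bromo. Nothing measured here gives a reason for this step.

As far as these compounds go, whether a butyl or longer chain in place of the propyl lowers the number further, or an amine there does the same, stays open. So does whether the ethyl change holds on the core of compound 1.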